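The compounds below may be only part of what the source reports. "The series", "measured", "known", "first", "only" and "open" are said of these compounds alone.

In an ADME assay on HEK293 cells (Homo sapiens) for cytotoxicity, read by resazurin assay, with a stated time of 48 h (a lower number here means that less compound is tolerated, a higher number that more compound is tolerated), compound 1 (`O=C(Nc1ccc(Sc2nc3ccccc3s2)c(Cl)c1)c1cccc(Br)c1O`) gives 68000 nM as its half-maximal cytotoxic concentration. Compound 3 (`COc1ccc(S(=O)(=O)Nc2ccc3oc(-c4ccc(NC(=O)C5CCN(C(C)=O)CC5)cc4)nc3c2)cc1`) reads 34000 nM and lies within the scatter of compound 1, as its nearest neighbour on these numbers. Compound 2 (`O=C(Nc1ccc(Sc2nc3ccccc3s2)cc1)c1cccc(Br)c1O`) reads 33000 nM and is the furthest from compound 1, only just beyond the scatter. Compound 1 therefore stands clear of compound 2 but not of compound 3.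

Compound 4 (`COc1c(Br)cccc1C(=O)Nc1ccc(Sc2nc3ccccc3s2)c(Cl)c1`) differs from compound 1 in one place, with methyl in place of hydrogen on an oxygen on an aromatic ring as the counted change, which is hydroxy to methoxy. Among the measured compounds shown here, no measured pair shows this change directly. For the measured compounds named here, only one measured step offers any guide, and a loose one: a 2.1-fold lower number from compound 1 to compound 2 (0.31 log units; beyond the scatter) is modest and comes from hydrogen in place of chloro on an aromatic carbon, so it does not touch the hydroxy. With so little to go on, no clear direction can be argued from these data. The estimated step is a 1.0-fold higher number from compound 1 to compound 4 (0.01 log units; within the scatter) and so no change beyond the scatter is expected in this assay for this pair. For compound 4 the expected value is 70000 nM with an estimated range from 30000 nM to 150000 nM as the measurement awaits.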

Compound 4, half-maximal cytotoxic concentration: 40000 nM
Compound 4: the middle estimate sits 1.8-fold (0.24 log units) above what was measured, and the stated range covers the measured number.
By their numbers in this assay, from the lowest: compounds 2, 3, 4 and 1 (each within the scatter of the next, the first and the last beyond it).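

Among the compounds shown here, replacing the hydroxy with methoxy gives the first reading of this oxygen in this assay: a 1.7-fold lower number from compound 1 to compound 4 (0.23 log units; within the scatter), so methyl in place of hydrogen on an oxygen on an aromatic ring produces no change beyond the scatter. For the compounds shown here, the one earlier step, a 2.1-fold lower number from compound 1 to compound 2 (0.31 log units; beyond the scatter), concerned the chloro and could say nothing about this position, whereas this pair shows that, with the chloro in place, the hydroxy hydrogen can be replaced by methyl without a readable effect on the number. Nothing measured here explains why the two compounds read as they do.

From the compounds shown here alone, whether the same change would also leave the number within the scatter in the absence of the chloro stays open, as the hydroxy to methoxy change is seen in this one pair only. How this assay would respond to a longer chain on this oxygen, such as ethyl, or to an amine or a carboxylic acid in place of the hydroxy also remains unknown from the compounds shown, so the limits of what this position allows are still undefined.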